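Amide Variation on a Shared Core: Expecting Compound 4

The compounds below may be only part of what the source reports. "The series", "measured", "known", "first", "only" and "open" are said of these compounds alone.

Measured compounds:
- compound 1, `COc1cc2c(cc1OC)C(CC(=O)O)CC2`, giving 44% in a functional assay on the whole organism (strain Swiss albino) for inhibition, with Mus musculus as the target, in the writhing test, with stated times of 60 min and 15 min, at a dose of 100 mg/kg by the oral route; on this read-out lower numbers stand for less inhibition and higher numbers for more inhibition at the one dose given (going by the name of the read-out)
- compound 2, `COc1cc2c(cc1OC)C(CC(N)=O)CC2`, giving 24.6% in this assay
- compound 3, `COc1cc2c(cc1OC)C(CC(=O)N(C)C)CC2`, giving 22.6% in this assay

Compound 2 stands second highest of the three numbers in this assay. Its nearest neighbour is compound 3, and the step of a number 2 percentage points lower from compound 2 to compound 3 (within the scatter) lies within the scatter. Compound 1 stands furthest away, and the step of a number 19.4 percentage points lower from compound 1 to compound 2 (beyond the scatter) goes beyond the scatter, as does a number 21.4 percentage points lower from compound 1 to compound 3 (beyond the scatter).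

Compound 4, `COc1cc2c(cc1OC)C(CC(=O)N1CCCCC1)CC2`, has not yet been measured. It differs from compound 2 in one place: piperidin-1-yl in place of amino on a carbonyl carbon.

For the measured compounds named here, the only measured step that bears on this change is the one from compound 2 to compound 3, where amino became dimethylamino on the same carbonyl carbon, and it stayed within the scatter. Swapping in a larger piperidin-1-yl group on that carbon is therefore expected to give a step of a number 2.6 percentage points lower from compound 2 to compound 4 (within the scatter) that is not beyond the scatter. Compound 4 is estimated at 22% in this assay, with a range from 8% to 38%.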

Compound 4, a percentage reported as inhibition, in the whole organism at one dose (the size of the read-out at that dose, not a potency): 44.7%
Beside the measured number, compound 4's estimate is 22.7 percentage points below it; the measured number lies above the stated range.
By their numbers in this assay, from the lowest: compounds 3 and 2 (each within the scatter of the next); then compounds 1 and 4 (each within the scatter of the next).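

Before this result, the amides on this carbonyl carbon looked interchangeable, but in this assay the step of a number 20.1 percentage points higher from compound 2 to compound 4 (beyond the scatter) and the step of a number 22.1 percentage points higher from compound 3 to compound 4 (beyond the scatter) show that the group attached through the amide nitrogen can matter. A free hydroxy on this carbon is also not needed to reach this level of inhibition, as the step of a number 0.7 percentage points higher from compound 1 to compound 4 (within the scatter) shows for piperidin-1-yl. Nothing available here explains why this amide differs from the two smaller ones.

The compounds shown leave open whether the ring itself counts or only the extra carbon atoms, a question that pyrrolidin-1-yl, morpholin-4-yl or diethylamino on the same carbonyl carbon could help to settle. With only one dose given, they also leave open how compound 4 and compound 1 would compare at other doses.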